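The source may hold more compounds than are shown below. What is called first, only, known or untested is meant among the compounds shown, and "the series" means these compounds.

Compound 2, `CC(C)c1onc(-c2ccccc2)c1COc1ccc(CCCCC(=O)O)cc1`, carries a 4-carboxybutyl chain on the far aromatic ring of its core. In an assay on HEK-293T cells for activation of Bile acid receptor (Homo sapiens), read by a luciferase reporter, with a stated time of 14 h (on this read-out lower numbers stand for an effect already at smaller amounts and higher numbers for an effect only at larger amounts of compound), compound 2 gives only a limit, > 30000 nM, not a number. This places compound 2 at the limit of > 30000 nM in this assay, at which 1 of the 2 values shown sits, so no true value is known for it. Among the compounds with values here, the one compound with a measured value, compound 1, `CC(C)c1onc(-c2ccccc2Cl)c1COc1ccc(COc2ccc(OCC(=O)O)cc2)cc1`, gives in this assay 4700 nM. Compound 3, `CC(C)c1onc(-c2ccccc2)c1COc1ccc(Oc2ccc(C(=O)O)cc2)cc1`, is not yet measured. It differs from compound 2 in one place: 4-carboxyphenoxy in place of 4-carboxybutyl on an aromatic carbon; the new group sits on an aromatic carbon of a six-membered aromatic ring of carbon only, para to a large group. Within the data shown here, no measured pair shows this kind of exchange, so the step can only be guessed. Since compound 2 sits at a limit, the step from compound 2 to compound 3 cannot be read off, but an improvement is expected, and the step of an at least 10-fold lower number from compound 2 to compound 3 (1.00 log units; beyond the scatter) is what that expectation amounts to. For compound 3 in this assay the estimate is 3000 nM, with a likely range from 500 nM to 20000 nM.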

Compound 3, half-maximal effective concentration: 11000 nM
For compound 3 the middle estimate is 3.7-fold (0.56 log units) below the measured one; measured number inside the range.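

On this aromatic carbon, 4-carboxyphenoxy in place of 4-carboxybutyl gives in this assay an at least 2.7-fold lower number from compound 2 to compound 3 (0.43 log units; beyond the scatter), so this one exchange moves the read-out by more than the usual scatter. Compound 3, at 11000 nM, also gives this position a true value, and it shows that a group holding a six-membered aromatic ring can sit here with a measurable effect. Compound 2 gives only a limit, so the step has a known minimum but no known size: the limit of > 30000 nM in this assay, at which 1 of the 3 values shown sits.

The compounds shown do not separate the parts of this exchange, since the ring, the extra oxygen and the larger size of the group all enter together, and a 4-carboxyphenyl group without the linking oxygen would be needed to tell the first two apart. As far as these compounds go, it also stays open whether the acid itself is needed at this position, a question that a compound ending in a primary amide or a tetrazole in place of the carboxylic acid could address.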